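Swapping methylamino for methyl on an iodo nucleoside

The source may report more compounds than this note shows. Statements on the series, on what has been measured and on what is new or still open speak of the compounds shown alone.

Values in a functional assay on A549 cells (Homo sapiens), read by MTT assay, with a stated time of 72 h; a higher number here means a weaker inhibitor, a lower number a stronger inhibitor:
Compound 1 `Cc1ncnc2c1c(-c1cccs1)cn2[C@@H]1O[C@H](CO)[C@@H](O)[C@H]1O`: > 20000 nM (a limit)
Compound 2 `C#Cc1cn([C@@H]2O[C@H](CO)[C@@H](O)[C@H]2O)c2ncnc(C)c12`: 19200 nM
Compound 3 `CNc1ncnc2c1c(I)cn2[C@@H]1O[C@H](CO)[C@@H](O)[C@H]1O`: > 100000 nM (a limit)

Compound 3 has no exact number, only a limit of > 100000 nM, the higher of the two limits shown. Compound 4 `Cc1ncnc2c1c(I)cn2[C@@H]1O[C@H](CO)[C@@H](O)[C@H]1O` differs from it as follows: methyl in place of methylamino on an aromatic carbon. Among the compounds with values here, no measured step makes this swap. Within the data shown here, the only measured step, an at least 1.0-fold lower number from compound 1 to compound 2 (0.01 log units; that floor lies within the scatter), lies at another place on the core and stays within the scatter. Compound 2, which already carries the methyl, reads 19200 nM. Compound 1, also with the methyl, reaches a limit of > 20000 nM. The step expected in this assay is an at least 4.0-fold lower number from compound 3 to compound 4 (0.60 log units; beyond the scatter), towards a lower number. For compound 4 the estimate is 25000 nM, with an expected range from 6000 nM to 100000 nM.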

Compound 4, half-maximal inhibitory concentration: 12200 nM
Compound 4: middle estimate off by 2.0-fold (0.31 log units), on the high side; measured number inside the range.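

In this assay, within the data shown here, this swap gives the first step that lies beyond the scatter: an at least 8.1-fold lower number from compound 3 to compound 4 (0.91 log units; beyond the scatter). That size is only a floor, because compound 3 has a limit and no exact number: the limit of > 100000 nM in this assay, at which 1 of the 4 values shown sits. Changing the group on the other aromatic carbon, with the methyl kept, gives a 1.6-fold lower number from compound 2 to compound 4 (0.20 log units; within the scatter) and an at least 1.6-fold lower number from compound 1 to compound 4 (0.21 log units; that floor lies within the scatter), so only the swap to methyl clearly moves the number.

The compounds shown leave open how a plain amine or an ethyl group would read here. They also leave open whether the swap gives a similar step when ethynyl or thiophen-2-yl replaces iodo.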